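The source may report more compounds than this note shows. Statements on the series, on what has been measured and on what is new or still open speak of the compounds shown alone.

The series gathers four compounds that share a core and differ in the substituents on the aromatic ring. Compound 2 `CSc1cc(F)ccc1NCC1=NCCN1` and compound 3 `CSc1c(F)cccc1NCC1=NCCN1` both carry a methylsulfanyl group and a fluoro group; the two have the same atoms joined differently, and the difference between the two cores is not broken down here. In an assay on CHO cells for binding affinity to Alpha-2C adrenergic receptor (Homo sapiens), read by radioligand binding (a lower number here means a stronger inhibitor, a higher number a weaker inhibitor), compound 2 gives 219 nM. In this assay compound 3 gives 219 nM, level with compound 2 within the scatter.

Compound 1 `CS(=O)(=O)c1cc(F)ccc1NCC1=NCCN1` is compound 2 with the change (methylsulfonyl in place of methylsulfanyl on an aromatic carbon). For compound 1 this assay reports only a limit, < 5020 nM, as shown by the limit of < 5020 nM in this assay, at which 1 of the 3 values shown sits. The step that the limit leaves unreadable from compound 2 to compound 1 is therefore not readable in size.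

Compound 4 `CS(=O)(=O)c1c(F)cccc1NCC1=NCCN1` awaits measurement. It is compound 3 with the change (methylsulfonyl in place of methylsulfanyl on an aromatic carbon), the same kind of change as from compound 2 to compound 1, though not the same: in compound 1 the place is meta to a fluoro group, in compound 4 it is ortho to a fluoro group. Since the earlier step is unreadable from compound 2 to compound 1, the expectation for compound 4 rests only on the direction of the limit of compound 1 and on the level of compound 3. In this assay compound 4 is expected to give about 3000 nM, between 600 nM and 15000 nM, a step of about a 14-fold higher number from compound 3 to compound 4 (1.14 log units; beyond the scatter), with a real chance that only a limit is reported.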

Compound 4, inhibition constant: 257 nM
For compound 4 the middle estimate is 12-fold (1.07 log units) above the measured one; the whole stated range lies above it.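

In this assay, putting methylsulfonyl in place of methylsulfanyl on an aromatic carbon ortho to a fluoro group gives a 1.2-fold higher number from compound 3 to compound 4 (0.07 log units; within the scatter), so on this core the change leaves the two compounds level. The same change on the other core cannot be read in size, because compound 1 is known only through a limit: the limit of < 5020 nM in this assay, at which 1 of the 4 values shown sits. Going by these compounds alone, the new step therefore shows that the change can be carried onto the core of compound 3 without a step beyond the scatter, but it does not show that the change acts alike on both cores, since only one of the two pairs gives a readable step and no comparison of the two steps can be made.

The compounds shown leave open how other groups would read at this same place on the shared core, for instance a nitrile, a carboxylic acid or an amine in place of the sulfur-bearing group. They also leave open whether the level seen for compound 3 and compound 4 would hold with a longer chain on the sulfur, such as ethylsulfonyl, or with chlorine in place of the fluoro group.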